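A Cyclobutyl Amide Replaces the Dimethylamino Chain

The compounds below may be only part of what the source reports. "The series", "measured", "known", "first", "only" and "open" are said of these compounds alone.

Compound 2 `CN(C)CC[C@@H]1C[C@@H](c2ccc(Cl)c(Cl)c2)[C@H](NC(=O)c2cc(-c3c(Cl)cnn3C)c(Cl)o2)CN1` gives 3.4 nM in an assay for inhibition of RAC-alpha serine/threonine-protein kinase (Homo sapiens), read by HTRF, with a stated time of 1 h; a higher number here means a weaker inhibitor, a lower number a stronger inhibitor. Compound 3 `CC(=O)OCC[C@@H]1C[C@@H](c2ccc(F)c(F)c2)[C@H](NC(=O)c2cc(-c3c(Cl)cnn3C)c(Cl)o2)CN1` gives 3.4 nM in this assay, level with compound 2 at the digits shown. Compound 1 `Cn1ncc(Cl)c1-c1cc(C(=O)N[C@@H]2CN[C@H](CC(O)CO)C[C@H]2c2ccc(Cl)c(Cl)c2)oc1Cl` gives 3.79 nM in this assay. The step of a 1.1-fold lower number from compound 1 to compound 2 (0.05 log units; within the scatter) lies within the scatter, so all three compounds stand together. Compound 4 `Cn1ncc(Cl)c1-c1cc(C(=O)N[C@@H]2CN[C@H](CC(=O)NC3CCC3)C[C@H]2c2ccc(Cl)c(Cl)c2)oc1Cl` differs from compound 2 by cyclobutylcarbamoyl in place of (dimethylamino)methyl on a saturated chain carbon bound to a saturated ring carbon. Among the measured compounds shown here, the only measured step at this position is the one between compound 1 and compound 2, where a change of the side chain left the number unmoved. On that basis compound 4 is expected to show no step beyond the scatter, a 1.2-fold higher number from compound 2 to compound 4 (0.07 log units; within the scatter). Compound 4 is therefore estimated at 4 nM, with a range from 1.5 nM to 11 nM.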

Compound 4, half-maximal inhibitory concentration: 7.98 nM
Beside the measured number, compound 4's estimate is 2.0-fold (0.30 log units) below it; the range from low to high includes it.
By their numbers in this assay, from the lowest: compounds 2, 3 and 1 (each within the scatter of the next); then compound 4.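

In this assay, among the compounds shown here, the steps of a 2.3-fold higher number from compound 2 to compound 4 (0.37 log units; beyond the scatter) and a 2.1-fold higher number from compound 1 to compound 4 (0.32 log units; beyond the scatter) are both modest, and they are the first at this position to lie beyond the scatter. The earlier swap of 1,2-dihydroxyethyl for (dimethylamino)methyl moved nothing beyond it, so this position is not indifferent to every group, and cyclobutylcarbamoyl costs some inhibition. No measurement shown here accounts for this shift. On these data alone, whether the step follows the cyclobutyl ring or the amide itself stays open. So does how a primary amine or a carboxylic acid on this chain would read.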